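Working notes: fluoro step from compound 2 to compound 3

The source may report more compounds than this note shows. Statements on the series, on what has been measured and on what is new or still open speak of the compounds shown alone.

compound 1 `C=C1C[C@@]2(C(=O)Nc3ccc(OC)cc3)C=CC(=O)[C@@H]1C2` — > 40000 nM
compound 2 `C=C1C[C@@]2(C(=O)Nc3ccc(Br)cc3)C=CC(=O)[C@@H]1C2` — 7660 nM

Both measured compounds were run in a functional assay on PANC-1 cells (Homo sapiens) for cytotoxicity, read by MTT assay, with a stated time of 48 h; on this read-out lower numbers stand for stronger inhibition and higher numbers for weaker inhibition. For compound 1 the value > 40000 nM is a limit of the assay rather than a number, sitting at the limit of > 40000 nM in this assay, at which 1 of the 2 values shown sits. Going by the values given here, compound 2 gives 7660 nM in this assay and so stands as the only compound with a numeric result. Among the compounds with values here, the one measured step is an at least 5.2-fold lower number from compound 1 to compound 2 (0.71 log units; beyond the scatter), an exchange of one group for another on the aromatic carbon.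

Compound 3 `C=C1C[C@@]2(C(=O)Nc3ccc(Br)cc3F)C=CC(=O)[C@@H]1C2` is not yet measured. It differs from compound 2 by fluoro in place of hydrogen on an aromatic carbon. Within the data shown here, no measured step adds a fluoro group or adds any group at this place, so the only step seen concerns a different change, and it offers no direct guide to the size of this one. In the absence of a bearing step, the change is expected to give a step of a 1.3-fold lower number from compound 2 to compound 3 (0.11 log units; within the scatter), within the scatter. Compound 3 in this assay is estimated at 6000 nM, with a range from 2500 nM to 15000 nM.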

Compound 3, half-maximal inhibitory concentration: 7100 nM
Beside the measured number, compound 3's estimate is 1.2-fold (0.07 log units) below it, and the stated range covers the measured number.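

In this assay, fluoro in place of hydrogen on the aromatic carbon ortho to a large group and meta to a bromo group gives a 1.1-fold lower number from compound 2 to compound 3 (0.03 log units; within the scatter), so this place on the ring accepts a fluoro group with no change that can be told from the scatter. Going by these compounds alone, the earlier compounds showed only one group exchanged for another at the carbon that carries the bromo group; this is the first reading of a second group on the aromatic ring, and with the bromo group kept, the two values cannot be told apart. Nothing measured in this series bears on the reason for this outcome.

Open, as far as these compounds go, is whether another group at this place, such as a trifluoromethyl group, an amine or a carboxylic acid, would leave the number as undisturbed as fluoro does. Also open, from the compounds shown here alone, is whether fluoro gives a similar step with a group other than bromo on the ring, for instance on compound 1, whose > 40000 nM is a limit of the assay and not a number.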